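The compounds below may be only part of what the source reports. "The series", "measured", "known", "first", "only" and "open" are said of these compounds alone.

Two compounds of the series have so far been run in an ADME assay on HeLa cells (Homo sapiens) for cytotoxicity, read by sulforhodamine B assay, with a stated time of 48 h, tested at 10 uM; a higher number here means more inhibition at the concentration tested (going by the name of the read-out), a lower number less inhibition. Compound 1 `CCCc1cn(C(c2ccccc2)c2cc3cc(Br)ccc3nc2OC)nn1` gives -2.25%. Compound 2 `COc1nc2ccc(Br)cc2cc1C(c1ccccc1)n1cc(-c2ccccc2C(F)(F)F)nn1` gives -1.3%. For the measured compounds named here, the single measured step, a number 1 percentage points higher from compound 1 to compound 2 (within the scatter), is within the scatter. On the numbers shown, compound 2 holds the higher of the two values, with compound 1 nearest to it and within the scatter, so the two are not set apart from each other in this assay.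

Compound 3 `COc1nc2ccc(Br)cc2cc1C(c1ccccc1)n1cc(CCCCCO)nn1` is not yet measured in this assay. It differs from compound 2 in one place: 5-hydroxypentyl in place of 2-(trifluoromethyl)phenyl on an aromatic carbon. Going by the values given here, the only step on record that bears on this, a number 1 percentage points higher from compound 1 to compound 2 (within the scatter), also exchanged the group on that aromatic carbon and stayed within the scatter, so no step beyond the scatter is expected here either. Compound 3 is therefore estimated at 0%, with a range from -12% to 12%, which means an expected step of a number 1.3 percentage points higher from compound 2 to compound 3 (within the scatter).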

Compound 3, a percentage reported as inhibition, at one concentration (the size of the read-out at that concentration, not a potency): 1.08%
For compound 3 the middle estimate is 1.1 percentage points below the measured one; the range from low to high includes it.
By their numbers in this assay, from the lowest: compounds 1, 2 and 3 (each within the scatter of the next).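

In this assay, 5-hydroxypentyl in place of 2-(trifluoromethyl)phenyl on the aromatic carbon of the five-membered ring gives a number 2.4 percentage points higher from compound 2 to compound 3 (within the scatter), so exchanging an aryl group for an open chain ending in hydroxyl, with a hydrogen-bond donor and acceptor entering, leaves the read-out inside the scatter. Extending the propyl chain with 2-hydroxyethyl in place of hydrogen gives a number 3.3 percentage points higher from compound 1 to compound 3 (within the scatter), so a change within the chain itself also sets no compound apart. No measurement is available that would explain this flat result.

As far as these compounds go, whether any group at this position can move the read-out beyond the scatter remains open, as all three compounds sit together. A terminal amine or carboxylic acid on the chain, or a much longer chain, could test this.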